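The source may hold more compounds than are shown below. What is called first, only, known or untested is meant among the compounds shown, and "the series" means these compounds.

Compound 1 `COC(=O)CC1CCN(C[C@H]2CN(c3ccc(-n4cc(-c5ccccn5)cn4)c(F)c3)C(=O)O2)CC1` is the starting point. In an ADME assay on HEK293-A cells (Homo sapiens) for cytotoxicity, read by MTT assay, with a stated time of 48 h (on this read-out higher numbers stand for weaker inhibition and lower numbers for stronger inhibition), compound 1 gives 224 ug/mL. Two measured compounds share its core and differ from it only on the saturated chain carbon bound to a saturated ring carbon. Compound 3 `O=C1O[C@@H](Cn2ccnn2)CN1c1ccc(-n2cc(-c3ccccn3)cn2)c(F)c1` carries 1H-1,2,3-triazol-1-yl there; in this assay compound 3 gives 225 ug/mL, and the step of a 1.0-fold higher number from compound 1 to compound 3 (0.00 log units; within the scatter) shows that compound 1 and compound 3 stand together among the two numbers shown. Compound 2 `O=C1O[C@@H](CSc2cccs2)CN1c1ccc(-n2cc(-c3ccccn3)cn2)c(F)c1` carries (thiophen-2-yl)sulfanyl there. In this assay compound 2 reports only a limit, > 400 ug/mL. The step of an at least 1.7-fold higher number from compound 1 to compound 2 (0.25 log units; that floor lies within the scatter) rests on (the limit of > 400 ug/mL in this assay, at which 1 of the 3 values shown sits). Compound 4 `NC(=O)[C@H]1CN(c2ccc(-n3cc(-c4ccccn4)cn3)c(F)c2)C(=O)O1` has not yet been measured. It differs from compound 1 in one place: carbamoyl in place of (4-((methoxycarbonyl)methyl)piperidin-1-yl)methyl on a saturated ring carbon. Both measured steps away from compound 1 remove the 4-((methoxycarbonyl)methyl)piperidin-1-yl group, and neither moved the number beyond the scatter, so for compound 4 no step beyond the scatter is expected in this assay, with a limit again possible. Compound 4 is estimated at 250 ug/mL, between 120 ug/mL and 450 ug/mL, a step of a 1.1-fold higher number from compound 1 to compound 4 (0.05 log units; within the scatter) that is expected to stay within the scatter.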

Compound 4, half-maximal inhibitory concentration: 152 ug/mL
For compound 4 the middle estimate is 1.6-fold (0.22 log units) above the measured one; measured number inside the range.
By their numbers in this assay, from the lowest: compounds 4, 1 and 3 (each within the scatter of the next). At a limit, above all of these: compound 2.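

In this assay, replacing the whole (4-((methoxycarbonyl)methyl)piperidin-1-yl)methyl group on the saturated ring carbon with carbamoyl leaves the number within the scatter, with a 1.5-fold lower number from compound 1 to compound 4 (0.17 log units; within the scatter). The comparison with the triazole compound agrees, with a 1.5-fold lower number from compound 3 to compound 4 (0.17 log units; within the scatter), so among compounds 1, 3 and 4 neither the size of the group nor the loss of the saturated chain carbon moves the read-out beyond the scatter. For the compounds shown here, the only step beyond the scatter, an at least 2.6-fold lower number from compound 2 to compound 4 (0.42 log units; beyond the scatter), is a floor set by a limit: the limit of > 400 ug/mL in this assay, at which 1 of the 4 values shown sits.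

The compounds shown leave open whether a carboxylic acid or an amine on this saturated ring carbon would move the number beyond the scatter in this assay. They also leave open how far compound 2 actually lies from compound 4.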